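Five-membered heteroaryl exchange on the chloro-substituted ring

The source may report more compounds than this note shows. Statements on the series, on what has been measured and on what is new or still open speak of the compounds shown alone.

The three measured compounds share one core and differ only in the five-membered aromatic ring attached to a six-membered aromatic ring of carbon only. Compound 1 `Cn1nc2c(=O)n(CC3(O)CCN(Cc4ccc(-c5ccc[nH]5)cc4Cl)CC3)cnc2c1-c1ccc(CN)cc1` carries a 1H-pyrrol-2-yl group, and in an assay on isolated protein for inhibition of ubiquitin carboxyl-terminal hydrolase 7 (Homo sapiens), with stated times of 30 min and 2 h (a higher number here means a weaker inhibitor, a lower number a stronger inhibitor), compound 1 gives 193 nM. Compound 2 `Cn1nc2c(=O)n(CC3(O)CCN(Cc4ccc(-c5cccs5)cc4Cl)CC3)cnc2c1-c1ccc(CN)cc1` carries a thiophen-2-yl group, and in this assay compound 2 gives 38.6 nM. Compound 3 `Cn1nc2c(=O)n(CC3(O)CCN(Cc4ccc(-c5ccsc5)cc4Cl)CC3)cnc2c1-c1ccc(CN)cc1` carries a thiophen-3-yl group, and in this assay compound 3 gives 59.5 nM, the second highest of the three numbers; the step of a 3.2-fold lower number from compound 1 to compound 3 (0.51 log units; beyond the scatter) lies beyond the scatter, while the step of a 1.5-fold higher number from compound 2 to compound 3 (0.19 log units; within the scatter) lies within it.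

Compound 4 `Cn1nc2c(=O)n(CC3(O)CCN(Cc4ccc(-c5ccc(C(=O)O)o5)cc4Cl)CC3)cnc2c1-c1ccc(CN)cc1` is not yet measured. Its change from compound 3 is 5-carboxyfuran-2-yl in place of thiophen-3-yl on an aromatic carbon. The measured steps bear on this only in part: a 5.0-fold lower number from compound 1 to compound 2 (0.70 log units; beyond the scatter) and a 3.2-fold lower number from compound 1 to compound 3 (0.51 log units; beyond the scatter) show that exchanging one five-membered ring for another moves the number by a modest amount, and a 1.5-fold higher number from compound 2 to compound 3 (0.19 log units; within the scatter) shows that moving the attachment point stays within the scatter. For the measured compounds named here, no measured step involves a furan or a carboxylic acid, so the direction is open and a step of modest size either way is possible. The expected step is a 1.7-fold higher number from compound 3 to compound 4 (0.23 log units; within the scatter), small and not firmly beyond the scatter. Compound 4 is therefore estimated at 100 nM, with a range from 30 nM to 400 nM.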

Compound 4, half-maximal inhibitory concentration: 753 nM
Compound 4: the middle estimate sits 7.5-fold (0.88 log units) below what was measured; the whole stated range lies below it.
By their numbers in this assay, from the lowest: compounds 2 and 3 (each within the scatter of the next); then compound 1; then compound 4.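

In this assay, for the compounds shown here, this position, para to a large group and meta to a chloro group, proves far less forgiving than the pyrrole and thiophene exchanges suggested: a 13-fold higher number from compound 3 to compound 4 (1.10 log units; beyond the scatter) and a 20-fold higher number from compound 2 to compound 4 (1.29 log units; beyond the scatter) are both large, while the earlier steps among those rings were modest or within the scatter. The step of a 3.9-fold higher number from compound 1 to compound 4 (0.59 log units; beyond the scatter) is smaller but still beyond the scatter, which makes compound 4 the weakest inhibitor of the four and shows that a substituted five-membered ring here can cost more than any exchange among the three simpler rings. Going by these compounds alone, no measurement at hand accounts for this rise, and the single change replaces the ring and adds the carboxyl group together, so the two contributions cannot be told apart.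

The compounds shown leave open whether the rise belongs to the furan ring or to the carboxylic acid, a question that an unsubstituted furan-2-yl group and a thiophene carrying the same carboxylic acid would separate. Also open, as far as these compounds go, is whether a methyl ester or a primary amide in place of the carboxylic acid would keep the number close to those of the thiophenes, and whether an aminomethyl group on the same ring would behave differently.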